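Allyl ether to hemisuccinate ester at the phenolic oxygen

The source may hold more compounds than are shown below. What is called first, only, known or untested is meant among the compounds shown, and "the series" means these compounds.

Measured so far:
compound 1 `C=CCOc1c(C)c(C)c2c(c1C)CCC(C)(COc1ccc(/C=C3\SC(=O)NC3=O)cc1)O2`: 42%
compound 2 `C=CCOc1c(C)c(C)c2c(c1C)CCC(C)(COc1ccc(/C=C3\SC(=O)NC3=O)cc1OC)O2`: 5%

In a functional assay on MCF7 cells (Homo sapiens), tested at 5 uM (a higher number here means a weaker effect of the compound at the concentration tested, a lower number a stronger effect), compound 1 stands highest of the two numbers; the nearest is compound 2, with a number 37 percentage points lower from compound 1 to compound 2 (beyond the scatter). Compound 3 `Cc1c(C)c2c(c(C)c1OC(=O)CCC(=O)O)CCC(C)(COc1ccc(/C=C3\SC(=O)NC3=O)cc1)O2` differs from compound 1 in one place: (2-carboxyethyl)carbonyl in place of allyl on an oxygen on an aromatic ring. Going by the values given here, no measured step touches this oxygen; the only step known, from compound 1 to compound 2, sits on an aromatic carbon and gives no guide to the size or direction here. Compound 3 is therefore expected to stay near compound 1, with a step of a number 2 percentage points lower from compound 1 to compound 3 (within the scatter) and an estimate of 40%, between 12% and 70%.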

Compound 3, a percentage reported as activity, at one concentration (the size of the read-out at that concentration, not a potency): 98%
Compound 3: middle estimate off by 58 percentage points, on the low side; the whole stated range lies below it.
By their numbers in this assay, from the lowest: compound 2; then compound 1; then compound 3.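

The oxygen on an aromatic ring proves to be a sensitive place in this assay: (2-carboxyethyl)carbonyl in place of allyl gives a number 56 percentage points higher from compound 1 to compound 3 (beyond the scatter), which means a much weaker effect at the concentration tested. The earlier step, on an aromatic carbon, strengthened the effect, so this oxygen is a second place that moves the read-out, here in the opposite direction. Nothing at hand explains this step.

On these data alone, whether the weakening follows the ester link or the acid end of the chain stays open. An acetyl ester, a free hydroxyl or a longer ether chain on this oxygen would separate the two.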